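Chlorophenyl in Place of Benzyloxy on Compound 1

This account rests on a few compounds, and the source may have more. Where it says the series, first, only, none or still open, it means among the compounds named here.

Compound 1 `C=C[C@@](C)(/C=C/c1ccc(OCc2ccccc2)cc1)CCC=C(C)C`: > 36600 nM
Compound 2 `COc1ccc(/C=C/[C@@](C)(/C=C/c2ccc(O)c(C=O)c2)CCC=C(C)C)cc1`: 4550 nM
Compound 3 `COc1ccc(/C=C/[C@@](C)(/C=C/c2ccc(O)c(/C=C/C(=O)OC(C)(C)C)c2)CCC=C(C)C)cc1`: > 36600 nM

Of the compounds shown here, three have been measured in a functional assay on SEM cells (Homo sapiens) for cytotoxicity, with a stated time of 72 h; on this read-out higher numbers stand for an effect only at larger amounts of compound and lower numbers for an effect already at smaller amounts. Compound 1 gives only a limit, > 36600 nM, so no number is known for it. Compound 2 gives 4550 nM in this assay. Compound 3 gives only a limit, > 36600 nM, in this assay. For the measured compounds named here, the one step that joins two measured compounds, an at least 8.0-fold higher number from compound 2 to compound 3 (0.90 log units; beyond the scatter), concerns a change at a different place than the one followed here, and it ends at a limit, as does compound 1; both sit at the limit of > 36600 nM in this assay, at which 2 of the 3 values shown sit.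

Compound 4 `C=C[C@@](C)(/C=C/c1ccc(-c2ccc(Cl)cc2)cc1)CCC=C(C)C` differs from compound 1 by 4-chlorophenyl in place of benzyloxy on an aromatic carbon. Going by the values given here, no measured step covers this change, and compound 1 itself stands only at a limit, so the step cannot be read from the data. Compound 4 is therefore expected to give a value close to the limit, with a likely step that the limit leaves unreadable from compound 1 to compound 4, and its estimated value is 40000 nM, within 10000 nM to 200000 nM.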

Compound 4, half-maximal effective concentration: > 36600 nM
Compound 4: a limit, no number; the forecaster's own chance of this, stated with the estimate: 70%; the middle value is on the limit's open side.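

In this assay compound 4 gives > 36600 nM, which is a limit and not a number. Compound 1 also stands at a limit, so no step can be read between compound 1 and compound 4. The compounds shown leave open whether 4-chlorophenyl in place of benzyloxy changes the effect at all, as both compounds sit at the same limit: the limit of > 36600 nM in this assay, at which 3 of the 4 values shown sit.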